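The source may report more compounds than this note shows. Statements on the series, on what has been measured and on what is new or still open speak of the compounds shown alone.

Measured so far in an ADME assay (liver) for metabolic stability, with Liver microsome (Rattus norvegicus) as the target, using microsomes and NADPH, with a stated time of 30 min, tested at 1 uM; on this read-out higher numbers stand for fast clearance and lower numbers for slow clearance:
- Compound 1 `Nc1ccc(S(=O)(=O)N2CCN(c3ncc(C(O)(C(F)(F)F)C(F)(F)F)cc3-c3ccoc3)CC2)cn1`: 57 mL.min-1.g-1
- Compound 2 `Nc1ccc(S(=O)(=O)N2CCN(c3ncc(C(O)(C(F)(F)F)C(F)(F)F)cc3-c3cccc(F)c3)CC2)cn1`: 52 mL.min-1.g-1

Only these two compounds have been measured, and compound 2 at 52 mL.min-1.g-1 stands within the scatter of compound 1, so neither can be said to clear faster. The next compound, compound 3 `Nc1ccc(S(=O)(=O)N2CCN(c3ncc(C(O)(C(F)(F)F)C(F)(F)F)cc3-c3ccccc3O)CC2)cn1`, keeps the shared core and changes one group: 2-hydroxyphenyl in place of 3-fluorophenyl on an aromatic carbon. For the measured compounds named here, the one measured step that bears on this change is a 1.1-fold lower number from compound 1 to compound 2 (0.04 log units; within the scatter), which came from replacing furan-3-yl with 3-fluorophenyl on an aromatic carbon and lies within the scatter. That single step suggests that this assay may respond little to an exchange of aromatic groups at this place. However, no measured compound carries a 2-hydroxyphenyl group, and one step is thin evidence, so the range has to stay wide. The expected change is a 1.2-fold lower number from compound 2 to compound 3 (0.06 log units; within the scatter), which means no step beyond the scatter in either direction. For compound 3 the estimated value is 45 mL.min-1.g-1, with an expected range from 18 mL.min-1.g-1 to 100 mL.min-1.g-1.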

Compound 3, intrinsic clearance in microsomes: 125 mL.min-1.g-1
Beside the measured number, compound 3's estimate is 2.8-fold (0.44 log units) below it; measured number above the stated range.
By their numbers in this assay, from the lowest: compounds 2 and 1 (each within the scatter of the next); then compound 3.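

In this assay, for the compounds shown here, the 2-hydroxyphenyl group gives the first step at this place that lies beyond the scatter (a 2.4-fold higher number from compound 2 to compound 3 (0.38 log units; beyond the scatter)), and the comparison with furan-3-yl also lies beyond it (a 2.2-fold higher number from compound 1 to compound 3 (0.34 log units; beyond the scatter)), so the aromatic group on this carbon can alter the clearance number, though the steps are modest and both point towards faster clearance. The exchange of 3-fluorophenyl for 2-hydroxyphenyl keeps 7 heavy atoms in the group but replaces fluorine with oxygen, and the count moves from 0 hydrogen-bond donors and 0 hydrogen-bond acceptors to 1 of each, which describes the change without accounting for the result. No measurement shown here establishes what produces the higher number for compound 3.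

The compounds shown leave open whether the higher number goes with the hydroxy group itself or with its place on the phenyl ring, a question that a 3-hydroxyphenyl or a 2-methoxyphenyl group at this carbon would address. A 2-aminophenyl group would show whether a nitrogen-bearing group at the same ring place behaves in the same way.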